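Swapping pyridin-2-yl for thiophen-2-yl on the shared core

This account rests on a few compounds, and the source may have more. Where it says the series, first, only, none or still open, it means among the compounds named here.

Measured so far:
compound 1, `Oc1cccc(-c2cc(-c3ccco3)nc(-c3ccccc3Cl)c2)c1`: 2230 nM in a functional assay on HCT-15 cells (Homo sapiens) for cytotoxicity, read by CCK-8 assay and cell counting, with a stated time of 2 days; a higher number here means a weaker inhibitor, a lower number a stronger inhibitor
compound 2, `Oc1ccc(-c2cc(-c3cccs3)nc(-c3ccccc3Cl)c2)cc1`: 5430 nM in this assay
compound 3, `Oc1cccc(-c2cc(-c3ccccn3)nc(-c3ccccc3Cl)c2)c1`: "not determined" (no result reported) in this assay

Compound 3 stands without a number in this assay, so its position cannot be fixed against compound 1 or compound 2. Compound 4, `Oc1cccc(-c2cc(-c3cccs3)nc(-c3ccccc3Cl)c2)c1`, differs from compound 3 by one change: thiophen-2-yl in place of pyridin-2-yl on an aromatic carbon. Among the compounds with values here, with no measured step on this change, the expected size of the step in this assay is unknown; it may go in either direction or stay within the scatter. The estimate for compound 4 therefore rests on compound 1 and compound 2, which share the core and lie within the scatter of one another. Compound 4 is expected to give about 3200 nM, with a range from 900 nM to 12000 nM.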

Compound 4, half-maximal inhibitory concentration: 2790 nM
For compound 4 the middle estimate is 1.1-fold (0.06 log units) above the measured one, and the stated range covers the measured number.
By their numbers in this assay, from the lowest: compounds 1, 4 and 2 (each within the scatter of the next, the first and the last beyond it).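

In this assay, thiophen-2-yl in place of furan-2-yl gives a 1.3-fold higher number from compound 1 to compound 4 (0.10 log units; within the scatter), and 3-hydroxyphenyl in place of 4-hydroxyphenyl gives a 1.9-fold lower number from compound 2 to compound 4 (0.29 log units; within the scatter), so neither exchange separates its pair of compounds in this assay. Compound 3 has no number, so the exchange of pyridin-2-yl for thiophen-2-yl cannot be read. Nothing available explains these small steps.

The compounds shown leave open whether an amine or a carboxylic acid in place of the hydroxyl group, or a saturated ring in place of thiophen-2-yl, would produce a step beyond the scatter.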